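Swapping fluoro for ethoxy in a growth-inhibiting series

The source may report more compounds than this note shows. Statements on the series, on what has been measured and on what is new or still open speak of the compounds shown alone.

Of the compounds shown here, three sharing one core have been measured in a functional assay on MCF7 cells (Homo sapiens) for antiproliferative activity; on this read-out higher numbers stand for weaker inhibition of growth and lower numbers for stronger inhibition of growth. Compound 1 (`COc1ccc(-c2nc3cc(F)ccc3s2)cc1F`) gives 870 nM, the highest number of the three, and compound 2 (`Oc1ccc(-c2nc3cc(F)ccc3s2)cc1O`) gives 720 nM, a value within the usual scatter of compound 1. Compound 3 (`COCOc1ccc(-c2nc3cc(F)ccc3s2)cc1OC`) gives 65 nM, well beyond the scatter from compound 1 and a clearly stronger inhibition of growth.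

The next compound to be tested is compound 4 (`CCOc1cc(-c2nc3cc(F)ccc3s2)ccc1OC`). It is made from compound 1 by putting ethoxy in place of fluoro on an aromatic carbon, ortho to a methoxy group and meta to a large group: ethoxy in place of fluoro on an aromatic carbon. Going by the values given here, no measured pair shows this change directly, so any forecast is tentative. The nearest guide is compound 3, at 65 nM, which also has only oxygen-linked groups on that ring, as compound 4 will. Compound 2 goes against too simple a reading, since with its hydroxy groups compound 2 stays at 720 nM. A clear move towards stronger inhibition is therefore expected, with the estimated step of a 5.1-fold lower number from compound 1 to compound 4 (0.71 log units; beyond the scatter). Compound 4 is expected to give about 170 nM, with an estimated range from 45 nM to 650 nM.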

Compound 4, concentration for 50% growth inhibition: 80 nM
Compound 4: middle estimate off by 2.1-fold (0.33 log units), on the high side; the range from low to high includes it.
By their numbers in this assay, from the lowest: compounds 3 and 4 (each within the scatter of the next); then compounds 2 and 1 (each within the scatter of the next).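

Going by these compounds alone, this is the first pair that differs in one place only, so the effect of this change can now be read directly: putting ethoxy in place of fluoro on an aromatic carbon, ortho to a methoxy group and meta to a large group, gives an 11-fold lower number from compound 1 to compound 4 (1.04 log units; beyond the scatter) in this assay. The position is therefore not indifferent to what sits on it, and here the group with 3 heavy atoms goes with much stronger inhibition of growth than the single fluorine it replaces. No measurement in hand explains why the swap has so large an effect.

One pair cannot show whether the oxygen attached to the ring or the two-carbon chain beyond it matters more, as both enter together when fluoro leaves. On these data alone, it also remains open how far this position would accept other groups, such as the longer propoxy chain or an amine, and whether the same swap would have a step of similar size on a different substitution pattern.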